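Moving the Trifluoromethyl Group to a Different Ring Position

This account rests on a few compounds, and the source may have more. Where it says the series, first, only, none or still open, it means among the compounds named here.

Of the compounds shown here, two have so far been measured in an assay on membranes from liver for displacement of a labelled ligand from Glucagon receptor (Mus musculus), read by scintillation counting, with a stated time of 60 min; on this read-out lower numbers stand for stronger inhibition and higher numbers for weaker inhibition. Compound 1 `C[C@H](c1ccc(C(=O)NCCC(=O)O)cc1)N1C(=O)C(c2cccc(C3CC3)c2)=N[C@]12CC[C@@H](C(C)(C)C)CC2` gives 1700 nM. Among the measured compounds shown here, compound 2 `CC(C)(C)[C@H]1CC[C@]2(CC1)N=C(c1cccc(C(F)(F)F)c1)C(=O)N2Cc1ccc(C(=O)NCCC(=O)O)cc1` gives 10000 nM, which is the higher of the two numbers; compound 1 is its only neighbour, with a lower number, and the gap between these two compounds lies beyond the usual scatter. Compound 3 `CC(C)(C)[C@H]1CC[C@]2(CC1)N=C(c1ccc(C(F)(F)F)cc1)C(=O)N2Cc1ccc(C(=O)NCCC(=O)O)cc1` is made from compound 2 without adding or removing any atom: the same atoms are simply joined differently, (4-(trifluoromethyl)phenyl in place of 3-(trifluoromethyl)phenyl on a carbon with a double bond to nitrogen), that is, 4-(trifluoromethyl)phenyl in place of 3-(trifluoromethyl)phenyl on a carbon with a double bond to nitrogen. For the measured compounds named here, no measured pair shows what this shift of the trifluoromethyl group around the ring does, so the step it brings is expected to be modest and within the scatter, as a 1.3-fold lower number from compound 2 to compound 3 (0.10 log units; within the scatter) expresses. Compound 3 is therefore estimated to give about 8000 nM in this assay, with a plausible range from 2500 nM to 30000 nM.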

Compound 3, half-maximal inhibitory concentration: 9600 nM
Compound 3: the middle estimate sits 1.2-fold (0.08 log units) below what was measured, and the stated range covers the measured number.
By their numbers in this assay, from the lowest: compound 1; then compounds 3 and 2 (each within the scatter of the next).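

In this assay, among the compounds shown here, putting 4-(trifluoromethyl)phenyl in place of 3-(trifluoromethyl)phenyl on a carbon with a double bond to nitrogen gives a 1.0-fold lower number from compound 2 to compound 3 (0.02 log units; within the scatter), the first measured step at this position. Compound 2 and compound 3 therefore cannot be told apart, and, for this pair, moving the trifluoromethyl group between these two ring positions leaves no readable mark on the number. Nothing available here explains this result.

Going by these compounds, both compounds carry the same trifluoromethyl group, so it remains open what a different group on this phenyl ring, such as a methoxy group, a nitrile or an amine, would do at either ring position. On these data alone, it is also open whether the same shift would prove as silent in a compound built like compound 1, which has a cyclopropyl group on this phenyl ring and also differs from compound 2 and compound 3 in the group on the ring nitrogen.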